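Exchanging One Two-Ring Group on a Shared Core

The source may hold more compounds than are shown below. What is called first, only, known or untested is meant among the compounds shown, and "the series" means these compounds.

Compound 1 `CC(=O)N[C@@H]1CCC[C@H](C(=O)Nc2cc(-c3cnn4ccccc34)c(Cl)cn2)C1`: 45000 nM
Compound 2 `CC(=O)N[C@@H]1CCC[C@H](C(=O)Nc2cc(-c3cnn4c3CN(C)CC4)c(Cl)cn2)C1`: 870000 nM

In a physicochemical assay for solubility, in phosphate buffer, at pH 7.4 (a higher number here means a more soluble compound, a lower number a less soluble compound), compound 2 is the higher of the two measured compounds, at 870000 nM. Compound 3 `CC(=O)N[C@@H]1CCC[C@H](C(=O)Nc2cc(-c3cnn4c3OCCC4)c(Cl)cn2)C1` differs from it by one change: a group of 9 heavy atoms (6 carbon, 2 nitrogen, 1 oxygen; one five-membered aromatic ring with 2 hetero atoms, one six-membered non-aromatic ring with 2 hetero atoms) in place of a group of 10 heavy atoms (7 carbon, 3 nitrogen; one five-membered aromatic ring with 2 hetero atoms, one six-membered non-aromatic ring with 2 hetero atoms), on an aromatic carbon. For the measured compounds named here, the only measured step that bears on this is a 19-fold higher number from compound 1 to compound 2 (1.29 log units; beyond the scatter), a large step that also exchanged the group on this aromatic carbon. The entering group keeps the ring types of the leaving group, so only part of that step is expected to be lost. The expected change is a 3.5-fold lower number from compound 2 to compound 3 (0.54 log units; beyond the scatter). For compound 3 the estimated value is 250000 nM, with an expected range of 80000 nM to 700000 nM.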

Compound 3, solubility: 110000 nM
Beside the measured number, compound 3's estimate is 2.3-fold (0.36 log units) above it, and the stated range covers the measured number.
By their numbers in this assay, from the lowest: compound 1; then compound 3; then compound 2.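

In this assay the exchange at this aromatic carbon gives a 7.9-fold lower number from compound 2 to compound 3 (0.90 log units; beyond the scatter), even though the leaving and entering groups share the same ring types and hydrogen-bond counts, so these alone do not set the number here. Set against the group of compound 1, the oxygen-bearing group still gives a 2.4-fold higher number from compound 1 to compound 3 (0.39 log units; beyond the scatter), which places compound 3 between compound 1 and compound 2. No measurement shown explains either step. Still open, going by these compounds, is how a primary amine or a carboxylic acid on the six-membered non-aromatic ring would read in this assay on this shared core.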